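Swapping Selenium for Sulfur on a Furan Isoselenourea

A few compounds are considered here, and "the series" means these few. Any claim that something is new, unique, unknown or untested is made for them only; others in the source may bear on it.

In a functional assay on HT-29 cells (Homo sapiens) for cytotoxicity, read by MTT assay, with a stated time of 72 h (a higher number here means a weaker inhibitor of growth, a lower number a stronger inhibitor of growth), compound 3 `C[Se]/C(=N\C(=O)c1ccco1)NC(=O)c1ccco1` gives 0.05 nM, the lowest of the two numbers recorded; its nearest neighbour, compound 1 `C[Se]/C(=N\C(=O)c1cc2ccccc2s1)NC(=O)c1cc2ccccc2s1`, gives 5620 nM, a gap far beyond the usual scatter. Compound 2 `CS/C(=N\C(=O)c1ccno1)NC(=O)c1ccno1` gives > 100000 nM, which is a limit of the assay rather than a number, namely (the limit of > 100000 nM in this assay, at which 1 of the 3 values shown sits). Compound 4 `CS/C(=N\C(=O)c1ccco1)NC(=O)c1ccco1` has not yet been measured; it differs from compound 3 by a group of 2 heavy atoms (1 carbon, 1 sulfur; no ring) in place of a group of 2 heavy atoms (1 carbon, 1 selenium; no ring), on a carbon with a double bond to nitrogen, in words a group of 2 heavy atoms (1 carbon, 1 sulfur; no ring) in place of a group of 2 heavy atoms (1 carbon, 1 selenium; no ring), on a carbon with a double bond to nitrogen. Within the data shown here, no measured pair isolates this change. The step is nonetheless expected to be a marked loss of potency, a 10000-fold higher number from compound 3 to compound 4 (4.00 log units; beyond the scatter), while staying short of the limit. Compound 4 is estimated at 500 nM, with a range from 5 nM to 50000 nM.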

Compound 4, concentration for 50% growth inhibition: 77100 nM
Compound 4: the middle estimate sits 150-fold (2.19 log units) below what was measured; the whole stated range lies below it.
By their numbers in this assay, from the lowest: compound 3; then compound 1; then compound 4. At a limit, above all of these: compound 2.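

In this assay, among these compounds, a 1500000-fold higher number from compound 3 to compound 4 (6.19 log units; beyond the scatter) with the rest of the molecule unchanged, the first measured pair to isolate this change. On a carbon with a double bond to nitrogen, replacing the selenium-bearing group with methylsulfanyl therefore removes nearly all the growth inhibition seen in this pair. Nothing measured here accounts for the size of this step.

Going by these compounds, whether the same replacement costs as much on the core of compound 1 remains open. So does the effect of a longer chain on the selenium, or of an amine in its place.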